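Vero Cell Cytotoxicity of Four Closely Related Compounds

The source may hold more compounds than are shown below. What is called first, only, known or untested is meant among the compounds shown, and "the series" means these compounds.

Compound 1 `O=[N+]([O-])c1cn2c(n1)OC[C@@H](OCc1cc(-c3ccc(F)cc3)no1)C2` gives in an ADME assay on Vero cells (Chlorocebus sabaeus) for cytotoxicity, with a stated time of 72 h (a higher number here means a weaker inhibitor, a lower number a stronger inhibitor), only a limit of the assay, > 128000 nM.
Compound 2 `O=[N+]([O-])c1cn2c(n1)OC[C@@H](OCc1cc(-c3ccc(OC(F)(F)F)cc3)no1)C2` gives in this assay only a limit, > 128000 nM.
Compound 3 `O=[N+]([O-])c1cn2c(n1)OC[C@@H](OCc1cn(-c3ccc(F)cc3)nn1)C2` gives in this assay only a limit, > 128000 nM.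

None of these three values is a number; all three sit at the limit of > 128000 nM in this assay, at which 3 of the 3 values shown sit. The change from compound 1 to compound 2 is trifluoromethoxy in place of fluoro on an aromatic carbon. The step it made, a step that the two limits leave unreadable from compound 1 to compound 2, cannot be read, since both ends are limits. Compound 3 has a different core from compound 1, and that difference is not broken down here. Compound 4 `O=[N+]([O-])c1cn2c(n1)OC[C@@H](OCc1cn(-c3ccc(OC(F)(F)F)cc3)nn1)C2` has not yet been measured; it stands to compound 3 as compound 2 stands to compound 1, through (trifluoromethoxy in place of fluoro on an aromatic carbon), the same change at the same place. The expectation for compound 4 rests on compound 1 and compound 2 both sitting at the limit of > 128000 nM in this assay, at which 3 of the 3 values shown sit. Compound 4 is therefore expected to give 200000 nM, which would mean an expected step that the limit leaves unreadable from compound 3 to compound 4.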

Compound 4, half-maximal inhibitory concentration: > 128000 nM
Compound 4: no number, only a limit (the forecaster's own chance of this, stated with the estimate: 90%); the middle value does not contradict the limit.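

No step can be read from compound 3 to compound 4, since both values are limits and not numbers in this assay: the limit of > 128000 nM in this assay, at which 4 of the 4 values shown sit.

The compounds shown leave open at what concentration any of them would harm these cells, and whether trifluoromethoxy in place of fluoro changes that concentration.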